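This account rests on a few compounds, and the source may have more. Where it says the series, first, only, none or still open, it means among the compounds named here.

Working notes on the series. In an ADME assay on HepG2 2.2.15 cells (Homo sapiens) for cytotoxicity, read by luminescence, with a stated time of 3 days (a higher number here means that more compound is tolerated, a lower number that less compound is tolerated), compound 1 `O=C(Nc1ccc(F)c(Cl)c1)c1ccc(F)c(S(=O)(=O)N2CCSCC(O)C2)c1` gives 19000 nM. Compound 2 `O=C(Nc1ccc(F)c(Cl)c1)c1ccc(F)c(S(=O)(=O)N2CCCCCCC2O)c1` gives 7000 nM, the lower of the two numbers. Compound 3 `CN1CCN(S(=O)(=O)c2cc(C(=O)Nc3ccc(F)c(Cl)c3)ccc2F)CC(O)C1` differs from compound 2 on the sulfonyl sulfur: a group of 9 heavy atoms (6 carbon, 2 nitrogen, 1 oxygen; one seven-membered non-aromatic ring with 2 hetero atoms) in place of a group of 9 heavy atoms (7 carbon, 1 nitrogen, 1 oxygen; one eight-membered non-aromatic ring with 1 hetero atom), on a sulfonyl sulfur. For the measured compounds named here, only one measured step bears on this, a 2.7-fold lower number from compound 1 to compound 2 (0.43 log units; beyond the scatter), and it replaced one seven-membered non-aromatic ring with 2 hetero atoms by one eight-membered non-aromatic ring with 1 hetero atom. Compound 3 again carries the seven-membered ring type, so a rise of similar size in this assay is expected, on this single step only. The expected change is a 2.6-fold higher number from compound 2 to compound 3 (0.41 log units; beyond the scatter). For compound 3 the estimate is 18000 nM, with a range of 7000 nM to 50000 nM.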

Compound 3, half-maximal cytotoxic concentration: 31000 nM
The estimate for compound 3 lay 1.7-fold (0.24 log units) below the measured number, within the range that was stated.
By their numbers in this assay, from the lowest: compound 2; then compounds 1 and 3 (each within the scatter of the next).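

In this assay, the 6-hydroxy-4-methyl-1,4-diazepan-1-yl group on the sulfonyl sulfur gives a 4.4-fold higher number from compound 2 to compound 3 (0.65 log units; beyond the scatter), so a second pair now places the eight-membered ring at the lower number. Between the two seven-membered rings, the change gives a 1.6-fold higher number from compound 1 to compound 3 (0.21 log units; within the scatter), so the two hetero atom sets cannot be told apart in this assay. No measured data on these compounds bear on the reason for the differences. Still open, as far as these compounds go, is how a six-membered ring such as piperidine or morpholine would compare on the sulfonyl sulfur. The contribution of the hydroxyl also remains open, as every ring shown carries one.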